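Series notes: aryl halogen change, compound 2 to compound 3

This account rests on a few compounds, and the source may have more. Where it says the series, first, only, none or still open, it means among the compounds named here.

Measured so far:
compound 1 `CC1=CC[C@H](C(C)(C)NC(=S)N/N=C/c2ccccc2)CC1` — 8800 nM
compound 2 `CC1=CC[C@H](C(C)(C)NC(=S)N/N=C/c2ccc(F)cc2)CC1` — > 100000 nM (a limit)

In a functional assay on HT-29 cells (Homo sapiens) for inhibition, read by sulforhodamine B assay, with a stated time of 48 h (on this read-out lower numbers stand for stronger inhibition of growth and higher numbers for weaker inhibition of growth), compound 1 gives 8800 nM. For compound 2 the assay reports only a limit, > 100000 nM. For the measured compounds named here, the single measured step, an at least 11-fold higher number from compound 1 to compound 2 (1.05 log units; beyond the scatter), came with fluoro in place of hydrogen on an aromatic carbon, and it leaves compound 2 standing at the limit of > 100000 nM in this assay, at which 1 of the 2 values shown sits, so no number is known for it. Compound 3 `CC1=CC[C@H](C(C)(C)NC(=S)N/N=C/c2ccccc2Cl)CC1` carries 2-chlorophenyl in place of 4-fluorophenyl on a carbon with a double bond to nitrogen. Going by the values given here, no measured step covers the 2-chlorophenyl group, and the 4-fluorophenyl group it replaces is the one that sits at the limit; the expectation therefore leans on compound 1 as the nearest numbered point, with wide margins. Compound 3 is estimated at 25000 nM, between 6000 nM and 100000 nM. That estimate means an expected step of an at least 4.0-fold lower number from compound 2 to compound 3 (0.60 log units; beyond the scatter), though with a fair chance that only a limit is again reported.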

Compound 3, concentration for 50% growth inhibition: 71300 nM
Compound 3: the middle estimate sits 2.9-fold (0.46 log units) below what was measured; the measured number falls inside the stated range.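

A halogen on the aromatic ring now has a numbered cost: in this assay, the change to chloro gives an 8.1-fold higher number from compound 1 to compound 3 (0.91 log units; beyond the scatter), so both halogen-bearing compounds shown read weaker than the unsubstituted compound 1. Against the 4-fluorophenyl group, the change to 2-chlorophenyl reads only as an at least 1.4-fold lower number from compound 2 to compound 3 (0.14 log units; that floor lies within the scatter), so no order between these two compounds can be claimed. Compound 2 remains a limit and not a number: the limit of > 100000 nM in this assay, at which 1 of the 3 values shown sits.

The identity of the halogen and its place on the ring change together between compound 2 and compound 3, so their contributions cannot be separated here. As far as these compounds go, whether a methoxy group or an amine on the same ring would also give a higher number than compound 1 remains open.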